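The compounds below may be only part of what the source reports. "The series", "measured", "known", "first", "only" and "open" are said of these compounds alone.

Measured so far:
Compound 1 `COc1ccc(/C=C2/CN(C)/C(=N/c3ccc(Cl)cc3)S2)cc1`: 7600 nM
Compound 2 `COc1ccc(/C=C2\S/C(=N\c3ccc(Cl)cc3)N(C)C2=O)cc1`: 39300 nM

Both numbers come from a functional assay on MCF7 cells (Homo sapiens) for antiproliferative activity, read by MTT assay, with a stated time of 72 h; on this read-out higher numbers stand for weaker inhibition and lower numbers for stronger inhibition. Compound 2 holds the higher of the two numbers; compound 1 sits lower, and the gap between them is beyond the scatter. Among the compounds with values here, no step between measured compounds that differ in a single place is available: compound 1 and compound 2 differ in more than one place, so their two values show only what they show and carry no single-point comparison.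

Compound 3 `COc1ccc(/C=C2\S/C(=N\c3ccc(Br)cc3)N(C)C2=O)cc1` is not yet measured. It differs from compound 2 in one place: bromo in place of chloro on an aromatic carbon. Within the data shown here, no measured pair tests this change, so its size cannot be read off the data. In this assay a step no larger than the scatter is expected, with no preferred direction. For compound 3 the estimated value in this assay is 35000 nM, with a range from 15000 nM to 80000 nM. The step this estimate implies, a 1.1-fold lower number from compound 2 to compound 3 (0.05 log units; within the scatter), is expected to stay within the scatter.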

Compound 3, half-maximal inhibitory concentration: > 100000 nM
Compound 3: a limit, no number; the forecaster's own chance of this, stated with the estimate: 10%; middle value at least 2.8-fold (0.45 log units) away from the limit.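

In this assay, within the data shown here, the change from 4-chlorophenyl to 4-bromophenyl gives the first single-place comparison: an at least 2.5-fold higher number from compound 2 to compound 3 (0.40 log units; beyond the scatter). This shows that the position on the aromatic ring, para to a large group, is not indifferent to the choice of halogen: exchanging one heavy atom, with no change in ring count, hydrogen-bond donors, hydrogen-bond acceptors or net charge, moves the read-out beyond the scatter towards weaker inhibition. Compound 3 stands at a limit and not at a number, so the step gives a lower bound only and its full size stays unread: the limit of > 100000 nM in this assay, at which 1 of the 3 values shown sits.

Going by these compounds, whether a fluoro or methyl group at this place would read closer to compound 2 or to compound 3 remains open, so a single exchange cannot yet show a trend across substituents. Also open, on these data alone, is whether the same exchange from chloro to bromo gives a step of like size on the core of compound 1.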